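Solubility at neutral pH across a short amide series

The source may hold more compounds than are shown below. What is called first, only, known or untested is meant among the compounds shown, and "the series" means these compounds.

Compound 1, `CN1CCC(C(=O)N2Cc3c(NC(=O)c4ccco4)n[nH]c3C2(C)C)CC1` — > 225000 nM
Compound 2, `CN1CCC(C(=O)N2Cc3c(NC(=O)c4ccccc4)n[nH]c3C2(C)C)CC1` — > 225000 nM
Compound 3, `CN1CCC(C(=O)N2Cc3c(NC(=O)c4ccc(Cl)cc4)n[nH]c3C2(C)C)CC1` — > 225000 nM

Three compounds sharing one core have been examined in a physicochemical assay for solubility, at pH 7; a lower number here means a less soluble compound, a higher number a more soluble compound. In this assay compound 1 gives > 225000 nM, which is a limit of the assay rather than a number. For compound 2 the result is > 225000 nM, again a limit. Compound 3 likewise reaches > 225000 nM, also a limit, so compound 3 stands at the same ceiling as the other two, and no ranking among them can be read.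

The measured steps are a step that the two limits leave unreadable from compound 1 to compound 2, a step that the two limits leave unreadable from compound 1 to compound 3 and a step that the two limits leave unreadable from compound 2 to compound 3, none of which can be sized because of the limit of > 225000 nM in this assay, at which 3 of the 3 values shown sit.

The next compound, compound 4, `CN1CCC(C(=O)N2Cc3c(NC(=O)c4ccc(F)c(F)c4)n[nH]c3C2(C)C)CC1`, differs from compound 3 in that (3,4-difluorophenyl in place of 4-chlorophenyl on a carbonyl carbon). Within the data shown here, no measured step speaks directly to this change, and the three steps that exist are unreadable; the expectation is therefore that compound 4 stays at the ceiling, with an estimated step of a number no higher from compound 3 to compound 4 (the limit leaves the size open). Compound 4 is expected to show 225000 nM in this assay, within 120000 nM to 400000 nM.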

Compound 4, solubility: > 225000 nM
Compound 4: only a limit was reported; the forecaster's own chance of this, stated with the estimate: 80%; the middle value sits exactly at the limit.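

In this assay compound 4 gives > 225000 nM, again a limit, so its steps from compound 1, compound 2 and compound 3 cannot be read: the limit of > 225000 nM in this assay, at which 4 of the 4 values shown sit.

The compounds shown leave open any ranking of these four in this assay, and which group on the carbonyl carbon, if any, would give a readable number.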